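The compounds below may be only part of what the source reports. "The series", "measured", "known", "first", "only" and "open" are said of these compounds alone.

Compound 1, `COc1ccc(-c2cn(CC(=O)Nc3nccs3)nn2)cc1`, gives 510 nM in a functional assay on BMDM cells (Mus musculus, strain C57BL/6) for inhibition, with a stated time of 2 days; on this read-out lower numbers stand for stronger inhibition and higher numbers for weaker inhibition.
Compound 2, `COc1ccc(-c2cn(CC(=O)Nc3nc(C)cs3)nn2)cc1`, gives 3890 nM in this assay.
Compound 3, `O=C(Cn1cc(-c2cccs2)nn1)Nc1nccs1`, gives only a limit of > 30000 nM in this assay.

Compound 1 and compound 2 share one core and differ in a single place, (methyl in place of hydrogen on an aromatic carbon), and this change gave a 7.6-fold higher number from compound 1 to compound 2 (0.88 log units; beyond the scatter), a weakening of inhibition. Compound 3 rests on another core; the difference between the two cores is not broken down here. The value of compound 3 is a limit of the assay, not a number: the limit of > 30000 nM in this assay, at which 1 of the 3 values shown sits.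

Compound 4, `Cc1csc(NC(=O)Cn2cc(-c3cccs3)nn2)n1`, is not yet measured. It differs from compound 3 by methyl in place of hydrogen on an aromatic carbon, the same change already seen above. Compound 4 is expected to inhibit no better than compound 3, because the earlier step gave a 7.6-fold higher number from compound 1 to compound 2 (0.88 log units; beyond the scatter), so a step that the limit leaves unreadable from compound 3 to compound 4 is expected. Compound 4 is therefore estimated at 100000 nM, within 30000 nM to 500000 nM, most likely reported only as a limit.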

Compound 4, half-maximal inhibitory concentration: 40 nM
The estimate for compound 4 lay 2500-fold (3.40 log units) above the measured number; measured number outside the range, below it.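

In this assay, the change from 1,3-thiazol-2-yl to 4-methyl-1,3-thiazol-2-yl gave an at least 750-fold lower number from compound 3 to compound 4 (2.87 log units; beyond the scatter), a strengthening of inhibition. The same small change weakened inhibition on the core of compound 1 and strengthened it on the core of compound 3, so its effect did not carry from one core to the other in this series: the same change on two cores in this assay, a 7.6-fold higher number (0.88 log units; beyond the scatter) from compound 1 to compound 2 and an at least 750-fold lower number (2.87 log units; beyond the scatter) from compound 3 to compound 4, at least 5700-fold (3.75 log units) apart, beyond the scatter of two such steps. These two pairs do not show why the direction differs or what the change would do on any further core, and the value of compound 3 is only a limit of the assay, not a number: the limit of > 30000 nM in this assay, at which 1 of the 4 values shown sits.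

The compounds shown leave open whether only methyl gives this result on the core of compound 3. An ethyl group or a chlorine atom in the same place might or might not act alike.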